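From Piperidine Amide to Cyclopropylmethyl Amide on Compound 1

A few compounds are considered here, and "the series" means these few. Any claim that something is new, unique, unknown or untested is made for them only; others in the source may bear on it.

The study concerns a small set of aryl-thiophene amides built on a shared core. Compound 1 `O=C1C=CC(=O)C(c2cc(-c3ccc(C(=O)N4CCCCC4)s3)on2)=C1` carries a piperidin-1-yl group on the carbonyl carbon. In a functional assay on PC-3 cells (Homo sapiens) for cytotoxicity, read by XTT assay, with a stated time of 72 h (a higher number here means a weaker inhibitor, a lower number a stronger inhibitor), compound 1 gives > 30000 nM, which is a limit of the assay and not a number. Compound 2 `CCCN(C)C(=O)c1ccc(-c2cc(-c3cc(OC)ccc3OC)no2)s1` is a dimethoxyphenyl analogue with a methyl(propyl)amino amide. In this assay compound 2 gives > 30000 nM, again a limit. Compound 3 `CCN(CC)C(=O)c1ccc(-c2cc(-c3cc(OC)ccc3OC)no2)s1` carries a diethylamino amide on the same scaffold. In this assay compound 3 gives > 30000 nM, also a limit. For the measured compounds named here, the one step between measured compounds, a step that the two limits leave unreadable from compound 2 to compound 3, is therefore unreadable in size and direction, since (the limit of > 30000 nM in this assay, at which 3 of the 3 values shown sit).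

Compound 4 `O=C1C=CC(=O)C(c2cc(-c3ccc(C(=O)NCC4CC4)s3)on2)=C1` has not yet been measured. It differs from compound 1 by (cyclopropylmethyl)amino in place of piperidin-1-yl on a carbonyl carbon. The change at the amide in the measured pair of compound 2 and compound 3 gives no readable size, so no basis exists for expecting a step beyond the scatter. Compound 4 is therefore expected to sit at 40000 nM, with a range of 15000 nM to 120000 nM. The step this estimate implies, a step that the limit leaves unreadable from compound 1 to compound 4, is expected to be indistinguishable from none, with the outcome most likely reported again as a limit.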

Compound 4, half-maximal inhibitory concentration: > 30000 nM
Compound 4: only a limit was reported (the forecaster's own chance of this, stated with the estimate: 80%); the middle value is on the limit's open side.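

In this assay compound 4 gives > 30000 nM, which is a limit of the assay and not a number. The step between compound 1 and compound 4 cannot be read in size or direction, because both values are limits: the limit of > 30000 nM in this assay, at which 4 of the 4 values shown sit. The compounds shown leave open whether the group on the carbonyl carbon matters in this assay at all.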